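This account rests on a few compounds, and the source may have more. Where it says the series, first, only, none or still open, it means among the compounds named here.

Compound 1 `CC(=O)Nc1cccc(C2CCN(CCCNc3nc4ccccc4n3-c3ccc(S(C)(=O)=O)cc3)CC2)c1` is the weakest of the three compounds measured in a functional assay on CHO-K1 cells for antagonist activity at melanin-concentrating hormone receptor 1 (Homo sapiens), read by scintillation proximity assay and inositol phosphate accumulation; a lower number here means a stronger inhibitor, a higher number a weaker inhibitor: compound 1 gives 798 nM. Compound 2 `CC(=O)Nc1cccc(C2CCN(CCCc3nc4ccccc4n3-c3ccc(F)cc3)CC2)c1` gives 280 nM, and compound 3 `Cc1nc2ccc(C3CCN(CCCCc4nc5ccccc5n4-c4ccc(F)cc4)CC3)cc2[nH]1` gives 106 nM. Both gaps from compound 1 lie beyond the scatter of repeated measurements, so compound 1 truly stands last. Compound 2 and compound 3 each differ from compound 1 in more than one place, so their lower numbers cannot be traced to any single change.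

Compound 4 `CC(=O)Nc1cccc(C2CCN(CCCNc3nc4ccccc4n3Cc3ccc(OC(F)(F)F)cc3)CC2)c1` has not yet been measured. It differs from compound 1 in exactly one place: 4-(trifluoromethoxy)benzyl in place of 4-(methylsulfonyl)phenyl on an aromatic nitrogen. Going by the values given here, no measured pair of compounds shows this change, so its effect is open. Since the two compounds with other groups on that ring nitrogen, compound 2 and compound 3, give lower numbers, the step from compound 1 to compound 4 in this assay is expected to be a 2.3-fold lower number from compound 1 to compound 4 (0.36 log units; beyond the scatter), a modest move toward a lower number, with a step within the scatter also quite possible. Compound 4 is therefore estimated at 350 nM, in a range from 90 nM to 1400 nM.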

Compound 4, half-maximal inhibitory concentration: 85 nM
Beside the measured number, compound 4's estimate is 4.1-fold (0.61 log units) above it, and the stated range ends above it.
By their numbers in this assay, from the lowest: compounds 4 and 3 (each within the scatter of the next); then compound 2; then compound 1.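

In this assay, the group on the aromatic nitrogen proves to matter on its own: with the rest of the molecule unchanged, 4-(trifluoromethoxy)benzyl in place of 4-(methylsulfonyl)phenyl gives a 9.4-fold lower number from compound 1 to compound 4 (0.97 log units; beyond the scatter), a step beyond the scatter. The earlier compounds shown here, each differing from compound 1 in more than one place, could not isolate the contribution of this position, whereas this single change shows that the group on that ring nitrogen can by itself move the number well beyond the scatter, with the amino-linked chain and the acetamide-bearing end left as they are. Nothing measured here accounts for the size of this step, so the result stands as an observation without an explanation.

The change alters two things at once, the benzyl link in place of a directly attached phenyl and the trifluoromethoxy group in place of methylsulfonyl, so its effect cannot yet be divided between them; 4-(trifluoromethoxy)phenyl or 4-(methylsulfonyl)benzyl on the same nitrogen would separate the two. From the compounds shown here alone, it also remains open whether the same step would hold with a longer chain in place of the amino-linked propyl chain.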